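A few compounds are considered here, and "the series" means these few. Any claim that something is new, unique, unknown or untested is made for them only; others in the source may bear on it.

Measured compounds:
compound 1 `C=CCN1C(=O)C(CC(=O)c2ccc(F)cc2)S/C1=N\N=C\c1ccccc1` – 21500 nM
compound 2 `O=C(CC1S/C(=N\N=C\c2c(-c3ccccc3)[nH]c3ccccc23)NC1=O)c1ccccc1` – > 50000 nM

In an ADME assay on BJ cells (Homo sapiens) for cytotoxicity, read by fluorescence, with a stated time of 24 h (a lower number here means a stronger inhibitor, a higher number a weaker inhibitor), compound 1 gives 21500 nM. Compound 2 is a different case. For compound 2, the entry in this assay is a limit of the assay, > 50000 nM, and not a number. This is the limit of > 50000 nM in this assay, at which 1 of the 2 values shown sits, so compound 2 stands at the weak end of the two values shown, and nothing closer can be said of it.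

Compound 3 `CC(=O)OCCC1S/C(=N\N=C\c2c(-c3ccccc3)[nH]c3ccccc23)NC1=O` has not been measured in this assay. It differs from compound 2 in one place: acetoxymethyl in place of benzoyl on a saturated chain carbon bound to a saturated ring carbon. For the measured compounds named here, no step between two measured compounds is available to calibrate this change, so the expectation rests on compound 2 alone. Since compound 2 sits at the limit, the step that the limit leaves unreadable from compound 2 to compound 3 is expected to be none beyond the scatter, and compound 3 is likely to fall at the limit again. Compound 3 is therefore estimated to give about 60000 nM in this assay, with a range from 20000 nM to 200000 nM.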

Compound 3, half-maximal inhibitory concentration: 37100 nM
Estimate against measurement, compound 3: 1.6-fold (0.21 log units) above; the measured number falls inside the stated range.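

On the shared core of compound 2 and compound 3, a measured number is reached without the benzoyl group: with acetoxymethyl in its place, compound 3 gives 37100 nM in this assay. This change, on a saturated chain carbon bound to a saturated ring carbon, gives an at least 1.3-fold lower number from compound 2 to compound 3 (0.12 log units; that floor lies within the scatter), the first step read at this position. For compound 2 the entry is a limit and not a number, so the step is known only as a floor and its true size stays unknown: the limit of > 50000 nM in this assay, at which 1 of the 3 values shown sits.

The change removes an aromatic ring, shortens the group and adds an ester at once, so the compounds shown cannot say which of these features goes with the reading in this assay. For the compounds shown here, a carboxylic acid, an amine or a plain longer alkyl chain at this place would help separate those features, and compound 1 differs from both compounds in more than one place, so it gives no step that could settle the matter.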